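Purine glycinamide series: side-chain truncation

The source may report more compounds than this note shows. Statements on the series, on what has been measured and on what is new or still open speak of the compounds shown alone.

Measured so far:
- compound 1 `N=C(N)NCCC[C@H](NC(=O)CN(c1nc(Cl)nc2[nH]cnc12)C1CC1)C(=O)OCc1ccccc1`: 10.2%
- compound 2 `O=C(O)CC[C@H](NC(=O)CN(c1nc(Cl)nc2[nH]cnc12)C1CC1)C(=O)O`: 30.1%
- compound 3 `N=C(N)NCCC[C@H](NC(=O)CN(c1ncnc2c1ncn2C1CCCCO1)C1CC1)C(=O)OCc1ccccc1`: 38.2%

In a functional assay on the whole organism (Tail, strain ICR) with Mus musculus as the target, in the tail flick test, with a stated time of 120 min, at a dose of 25 umol/kg by the oral route (on this read-out lower numbers stand for a weaker effect and higher numbers for a stronger effect at the one dose given), compound 2 gives 30.1%, the second highest of the three numbers. Its nearest neighbour is compound 3, whose number lies within the scatter of compound 2, so no order can be read between these two. Compound 1 gives a number beyond the scatter below compound 2.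

Compound 4 `C[C@H](NC(=O)CN(c1nc(Cl)nc2[nH]cnc12)C1CC1)C(=O)O` is to be measured next. It differs from compound 2 in one place: hydrogen in place of carboxymethyl on a saturated chain carbon, two bonds along the chain from an amide-type nitrogen and a carbonyl carbon. Read one bond further out, this is a 2-carboxyethyl to methyl exchange, or 1,3-dicarboxypropyl to 1-carboxyethyl.

Among the measured compounds shown here, no measured pair isolates this change, so its size is unknown. With only one carboxymethyl removed and the rest of compound 2 kept, a modest downward step is expected, near the edge of the scatter, and the estimated step in this assay is a number 8.1 percentage points lower from compound 2 to compound 4 (within the scatter). Compound 4 is expected to give about 22%, between 8% and 38%.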

Compound 4, a percentage reported as activity, at one dose (the size of the read-out at that dose, not a potency): 28.4%
The estimate for compound 4 lay 6.4 percentage points below the measured number; measured number inside the range.
By their numbers in this assay, from the lowest: compound 1; then compounds 4, 2 and 3 (each within the scatter of the next).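

In this assay, among the compounds shown here, the exchange of carboxymethyl for hydrogen on this saturated chain carbon now has a measured size, the step of a number 1.7 percentage points lower from compound 2 to compound 4 (within the scatter) being the first matched pair. At this one dose and time, the carboxymethyl group is therefore not needed to keep the read-out of compound 4 within the scatter of compound 2, and the 1,3-dicarboxypropyl and 1-carboxyethyl forms cannot be told apart here. No measured property of either compound bears on this result.

Still open, going by these compounds, is whether an amine, a hydroxymethyl group or a longer chain on this carbon would stay within the scatter of compound 2 or move beyond it. On these data alone, the effect of the same exchange at other doses or times, or on another core, also remains unknown.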